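A few compounds are considered here, and "the series" means these few. Any claim that something is new, unique, unknown or untested is made for them only; others in the source may bear on it.

Measured compounds:
- compound 1 `O=C1OC(C(O)CO)C(OCCCO[N+](=O)[O-])=C1O` gives 454000 nM in a functional assay on cells (Hepatocyte, Rattus norvegicus, strain Wistar), using NADPH; a higher number here means a weaker inhibitor, a lower number a stronger inhibitor
- compound 2 `O=C1OC(C(O)CO)C(O)=C1OCCCOc1no[n+]([O-])c1-c1ccccc1` gives 392000 nM in this assay
- compound 3 `O=C1OC(C(O)CO)C(OCCCOc2no[n+]([O-])c2S(=O)(=O)c2ccccc2)=C1O` gives 80000 nM in this assay

Among these three, compound 3 stands at the lowest number, and its gaps to compound 2 and to compound 1 both lie beyond the usual scatter of this assay, so it is the strongest inhibitor seen so far. Compound 1 and compound 2 sit within the scatter of each other, so no order between them can be read.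

Compound 4 `O=C1OC(C(O)CO)C(OCCCOc2no[n+]([O-])c2-c2ccccc2)=C1O` has not yet been measured in this assay. It differs from compound 3 in one place: phenyl in place of phenylsulfonyl on an aromatic carbon. Going by the values given here, since no step between measured compounds is known, the direction can only be guessed. Compound 2 also carries a phenyl on its five-membered ring and gives 392000 nM, a much higher number than compound 3. Compound 4 is therefore expected to lose potency, with a step of a 3.8-fold higher number from compound 3 to compound 4 (0.57 log units; beyond the scatter) beyond the scatter. Compound 4 is estimated at 300000 nM, within a range from 100000 nM to 900000 nM.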

Compound 4, half-maximal inhibitory concentration in the Hepatocyte assay: 17000 nM
Compound 4: middle estimate off by 18-fold (1.25 log units), on the high side; measured number below the stated range.
By their numbers in the Hepatocyte assay, from the lowest: compound 4; then compound 3; then compounds 2 and 1 (each within the scatter of the next).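

Phenyl in place of phenylsulfonyl on this aromatic carbon gives the first reading of a single change at this position, and in the Hepatocyte assay it yields a stronger inhibitor, with a 4.7-fold lower number from compound 3 to compound 4 (0.67 log units; beyond the scatter). The same change also shifts a second measurement: in a physicochemical assay for lipophilicity, using the shake flask method, with a stated time of 4 h, at pH 1.0 (a higher number here means a more lipophilic compound, a lower number a more polar compound), compound 3 gives 1.18 and compound 4 gives 1.53. The stronger inhibitor is thus also the more lipophilic compound: the measured distribution coefficient of compound 3, 1.18, and of compound 4, 1.53, a number 0.35 log units higher (beyond the scatter)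

This single pair cannot tell whether the potency follows lipophilicity or depends on the group itself. The compounds shown also leave open how an amine, a carboxylic acid or a nitrile on this aromatic carbon would compare with phenyl.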